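A few compounds are considered here, and "the series" means these few. Any claim that something is new, unique, unknown or untested is made for them only; others in the source may bear on it.

The measured compounds:
compound 1 `O=[N+]([O-])c1cccc(COc2ccc(OCCOCCNC3CCCC3)cc2)c1`: 15400 nM
compound 2 `O=C(O)c1ccc(COc2ccc(OCCOCCNC3CCCC3)cc2)cc1`: a limit, > 100000 nM
compound 3 `CCOc1ccc(OCCOCCNC2CCCC2)cc1`: 90500 nM

In a functional assay on SK-OV-3 cells (Homo sapiens) for inhibition, read by CCK-8 assay, with a stated time of 70 h (on this read-out lower numbers stand for stronger inhibition and higher numbers for weaker inhibition), compound 1 gives 15400 nM. Compound 2 reached only the limit of this assay, > 100000 nM, which is a ceiling and not a number (the limit of > 100000 nM in this assay, at which 1 of the 3 values shown sits). Compound 3 gives 90500 nM, the highest of the two plain numbers; its nearest neighbour is compound 1, and a 5.9-fold higher number from compound 1 to compound 3 (0.77 log units; beyond the scatter).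

Compound 4 `COC(=O)c1ccccc1COc1ccc(OCCOCCNC2CCCC2)cc1` differs from compound 3 in one place: 2-(methoxycarbonyl)phenyl in place of methyl on a saturated chain carbon bound to an oxygen on an aromatic ring. Going by the values given here, two measured steps bear on this change. The step of a 5.9-fold higher number from compound 1 to compound 3 (0.77 log units; beyond the scatter) shows that an aromatic ring carrying a nitro group at this place gives a modest improvement, whereas an at least 1.1-fold lower number from compound 2 to compound 3 (0.04 log units; that floor lies within the scatter) shows that an aromatic ring carrying a carboxylic acid gives none. The incoming 2-(methoxycarbonyl)phenyl group is an aromatic ring with an ester rather than an acid, so a step of intermediate size toward a lower number is expected: a 2.3-fold lower number from compound 3 to compound 4 (0.35 log units; beyond the scatter). Compound 4 is therefore estimated at 40000 nM, with a range of 10000 nM to 100000 nM.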

Compound 4, half-maximal inhibitory concentration: > 100000 nM
Compound 4 gave a limit, no number; the forecaster's own chance of this, stated with the estimate: 25%; at least 2.5-fold (0.39 log units) between middle value and limit.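

In this assay the result for compound 4 is a limit and not a number, the second such limit among these compounds: the limit of > 100000 nM in this assay, at which 2 of the 4 values shown sit. Compared with the methyl of compound 3, the 2-(methoxycarbonyl)phenyl group gives no gain that can be read, with an at least 1.1-fold higher number from compound 3 to compound 4 (0.04 log units; that floor lies within the scatter). The 3-nitrophenyl group of compound 1 still stands clearly ahead, with an at least 6.4-fold higher number from compound 1 to compound 4 (0.81 log units; beyond the scatter), so an aromatic ring at this place does not bring a lower number by itself, and compound 2 and compound 4 both go against any such pattern.

The step from compound 2 to compound 4 cannot be read, as both values are limits. Going by these compounds, whether the lower number of compound 1 is tied to the nitro group stays open, and a plain phenyl ring, or one carrying an amine or a nitrile, could help to settle it.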